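Benzothiazolyl pyrazole carboxamides: methyl for methoxy, second pairing

The source may report more compounds than this note shows. Statements on the series, on what has been measured and on what is new or still open speak of the compounds shown alone.

Measured so far in a functional assay on PC-3 cells (Homo sapiens) for cytotoxicity, read by MTT assay, with a stated time of 72 h; a lower number here means a stronger inhibitor, a higher number a weaker inhibitor:
- compound 1 `COc1ccc2nc(NC(=O)c3cn(-c4ccccc4)nc3-c3ccc(Cl)cc3)sc2c1`, 29300 nM
- compound 2 `Cc1ccc2nc(NC(=O)c3cn(-c4ccccc4)nc3-c3ccc(Cl)cc3)sc2c1`, 14500 nM
- compound 3 `COc1ccc(-c2nn(-c3ccccc3)cc2C(=O)Nc2nc3ccc(OC)cc3s2)cc1`, 13500 nM

The step of a 2.0-fold lower number from compound 1 to compound 2 (0.31 log units; beyond the scatter) follows the change (methyl in place of methoxy on an aromatic carbon). The step of a 2.2-fold lower number from compound 1 to compound 3 (0.34 log units; beyond the scatter) follows the change (methoxy in place of chloro on an aromatic carbon), which is also how the core of compound 3 differs from the core of compound 1. Compound 2 and compound 3 give numbers within the scatter of each other, so no order between them is read.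

Compound 4 `COc1ccc(-c2nn(-c3ccccc3)cc2C(=O)Nc2nc3ccc(C)cc3s2)cc1` is not yet measured. It differs from compound 3 by methyl in place of methoxy on an aromatic carbon, the same change as from compound 1 to compound 2, made on the core of compound 3 instead. Going by the values given here, only one earlier instance exists, so the expectation rests on a single step. From compound 3 to compound 4 a step of about a 2.0-fold lower number from compound 3 to compound 4 (0.30 log units; within the scatter) is expected in this assay, because the same change gave a 2.0-fold lower number from compound 1 to compound 2 (0.31 log units; beyond the scatter). Compound 4 is therefore estimated at 6800 nM, with a likely range from 3000 nM to 15000 nM.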

Compound 4, half-maximal inhibitory concentration: 15900 nM
Beside the measured number, compound 4's estimate is 2.3-fold (0.37 log units) below it; the whole stated range lies below it.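

On the core of compound 3, methyl in place of methoxy gives a 1.2-fold higher number from compound 3 to compound 4 (0.07 log units; within the scatter) in this assay, and methoxy in place of chloro, read on the core of compound 2, gives a 1.1-fold higher number from compound 2 to compound 4 (0.04 log units; within the scatter); both new steps lie within the scatter. The methyl-for-methoxy step does not differ measurably between the two cores, so the data neither establish that the change carries its size across cores nor establish that it fails to: the same change on two cores in this assay, a 2.0-fold lower number (0.31 log units; beyond the scatter) from compound 1 to compound 2 and a 1.2-fold higher number (0.07 log units; within the scatter) from compound 3 to compound 4, 2.4-fold (0.38 log units) apart, within the scatter of two such steps. The same reading holds for methoxy in place of chloro, and with only one pair of cores for each change, nothing is shown about how either change behaves on any other core: the same change on two cores in this assay, a 2.2-fold lower number (0.34 log units; beyond the scatter) from compound 1 to compound 3 and a 1.1-fold higher number (0.04 log units; within the scatter) from compound 2 to compound 4, 2.4-fold (0.38 log units) apart, within the scatter of two such steps.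

Still open, on these data alone, is whether a group of another kind at the place of the methoxy or methyl group on the benzothiazole, such as an amine, a carboxylic acid or a longer chain, would give a step clearly beyond the scatter. Also open, as far as these compounds go, is how changes elsewhere on the shared core would read in this assay.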